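Replacing the sulfonamide arm on the triazole: expected cytotoxicity

The source may hold more compounds than are shown below. What is called first, only, known or untested is meant among the compounds shown, and "the series" means these compounds.

Measured so far:
compound 1, `CC(C)(C)c1cn(C[C@H](O)[C@H]2OC(=O)C(OCc3ccccc3)=C2OCc2ccccc2)nn1`: 13300 nM
compound 2, `COc1ccc(-c2cn(C/C=C3\OC(=O)C(OCc4ccccc4)=C3OCc3ccccc3)nn2)cc1`: a limit of the assay, > 100000 nM
compound 3, `Cc1ccc(S(=O)(=O)NCc2cn(C[C@H](O)[C@H]3OC(=O)C(OCc4ccccc4)=C3OCc3ccccc3)nn2)cc1`: 50 nM

In an ADME assay on HFF cells (Homo sapiens) for cytotoxicity, read by MTT assay, with a stated time of 72 h (a higher number here means a weaker inhibitor, a lower number a stronger inhibitor), compound 3 gives 50 nM, the lowest of the two numbers shown. Its nearest neighbour is compound 1 with 13300 nM, and the step of a 270-fold lower number from compound 1 to compound 3 (2.42 log units; beyond the scatter) is large. For compound 2 the assay reports only a limit, > 100000 nM.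

Compound 4, `O=C1O[C@H]([C@@H](O)Cn2cc(-c3cccc(O)c3)nn2)C(OCc2ccccc2)=C1OCc1ccccc1`, differs from compound 3 in one place: 3-hydroxyphenyl in place of (((4-methylphenyl)sulfonyl)amino)methyl on an aromatic carbon. Going by the values given here, the one measured step at this place, a 270-fold lower number from compound 1 to compound 3 (2.42 log units; beyond the scatter), shows the (((4-methylphenyl)sulfonyl)amino)methyl group bringing a large fall in the number. Its removal in compound 4 is therefore expected to raise the number by a large step, a 200-fold higher number from compound 3 to compound 4 (2.30 log units; beyond the scatter). Compound 4 is estimated at 10000 nM, between 1500 nM and 60000 nM.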

Compound 4, half-maximal inhibitory concentration: 39000 nM
Compound 4: middle estimate off by 3.9-fold (0.59 log units), on the low side; low and high end bracket the measured number.
By their numbers in this assay, from the lowest: compound 3; then compound 1; then compound 4. At a limit, above all of these: compound 2.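

Replacing the (((4-methylphenyl)sulfonyl)amino)methyl arm gives a 780-fold higher number from compound 3 to compound 4 (2.89 log units; beyond the scatter), so the low number of compound 3 does not carry over to 3-hydroxyphenyl, although that group also has a six-membered aromatic ring of carbon only and a hydrogen-bond donor. Against tert-butyl, the same group gives a 2.9-fold higher number from compound 1 to compound 4 (0.47 log units; beyond the scatter), a modest step, so among these three groups the sulfonyl-bearing arm stands apart. No measurement shown bears on the cause of this difference. From the compounds shown here alone, what an amine or a carboxylic acid at this place would give stays open, as does whether the sulfonyl group or the 4-methylphenyl ring within the arm carries the low number.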